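A few compounds are considered here, and "the series" means these few. Any claim that something is new, unique, unknown or untested is made for them only; others in the source may bear on it.

Measured so far in a functional assay on HEp-2 cells (Homo sapiens) for antiproliferative activity, read by MTT assay, with a stated time of 72 h; on this read-out higher numbers stand for weaker inhibition and lower numbers for stronger inhibition:
- compound 1 `Cc1ccc2c(=O)c(CSC(=S)N(C(C)C)C(C)C)coc2c1`: 700 nM
- compound 2 `CC(C)N(C(=S)SCc1coc2cc(Cl)ccc2c1=O)C(C)C`: 4200 nM
- compound 3 `O=c1cc(CSC(=S)N2CCOCC2)oc2ccccc12`: a limit of the assay, > 25000 nM

Compound 1 holds the lowest of the two numbers; its nearest neighbour is compound 2, reached by a 6.0-fold higher number from compound 1 to compound 2 (0.78 log units; beyond the scatter), a change on the aromatic ring only. Compound 4 `Cc1ccc2c(=O)c(CSC(=S)N3CCCC3)coc2c1` differs from compound 1 by pyrrolidin-1-yl in place of diisopropylamino on a thiocarbonyl carbon. Going by the values given here, no measured step varies the group on the thiocarbonyl carbon, so the one measured step bears only indirectly. Compound 3, which carries morpholino there on a core differing in two places, sits at the limit of > 25000 nM in this assay, at which 1 of the 3 values shown sits. A cyclic amine on the thiocarbonyl is thus expected to cost potency, and compound 4 is estimated at 3000 nM (range 800 nM to 12000 nM), a step of a 4.3-fold higher number from compound 1 to compound 4 (0.63 log units; beyond the scatter) beyond the scatter.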

Compound 4, half-maximal inhibitory concentration: 3600 nM
Beside the measured number, compound 4's estimate is 1.2-fold (0.08 log units) below it, and the stated range covers the measured number.
By their numbers in this assay, from the lowest: compound 1; then compounds 4 and 2 (each within the scatter of the next). At a limit, above all of these: compound 3.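

In this assay, the group on the thiocarbonyl carbon now has a step of its own, with pyrrolidin-1-yl in place of diisopropylamino on an unchanged core: a 5.1-fold higher number from compound 1 to compound 4 (0.71 log units; beyond the scatter). This position is therefore not indifferent to the amine, and the change here matters as well as the aromatic substituent. Compound 3, with morpholino on a different core, remains a limit of the assay rather than a number: the limit of > 25000 nM in this assay, at which 1 of the 4 values shown sits.

From the compounds shown here alone, it remains open whether the ring itself or the loss of carbon atoms accounts for the step. Diethylamino, piperidin-1-yl or morpholino on the core of compound 1 would separate these readings.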